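A longer basic chain on the acylguanidine of compound 1

This account rests on a few compounds, and the source may have more. Where it says the series, first, only, none or still open, it means among the compounds named here.

Compound 1 `COc1ccc(Br)cc1CCc1c(F)cccc1C(=O)/N=C(\N)NCCN1CCCC1` was studied in an assay for binding affinity to Melanocortin receptor 4 (Homo sapiens) (on this read-out lower numbers stand for stronger inhibition and higher numbers for weaker inhibition), where compound 1 gives 190 nM. This is the higher of the two numbers recorded so far; its nearest neighbour is compound 2 `CCN(CC)CCCC(C)/N=C(/N)NC(=O)c1cccc(F)c1CCc1cc(Br)ccc1OC`, which in this assay gives 4.3 nM, a far lower number, well beyond the usual scatter. Compound 2 carries a different and longer amine chain. Compound 3 `COc1ccc(Br)cc1CCc1c(F)cccc1C(=O)/N=C(\N)NCCCCN1CCCCC1` differs from compound 1 in one place: 2-(piperidin-1-yl)ethyl in place of pyrrolidin-1-yl on a saturated chain carbon, two bonds along the chain from an amine nitrogen. Among the measured compounds shown here, no measured pair shows exactly this change, so the expectation rests on compound 2, whose longer amine chain goes together with 4.3 nM. On that basis compound 3 is expected to give a lower number than compound 1, with the step of a 3.8-fold lower number from compound 1 to compound 3 (0.58 log units; beyond the scatter) expected to reach beyond the scatter, though not as far as compound 2 went. The estimate for compound 3 is 50 nM, within a range from 10 nM to 250 nM.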

Compound 3, inhibition constant: 0.58 nM
Estimate against measurement, compound 3: 86-fold (1.94 log units) above, outside the stated range (below it).
By their numbers in this assay, from the lowest: compound 3; then compound 2; then compound 1.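

Among the compounds shown here, on a saturated chain carbon, two bonds along the chain from an amine nitrogen, the swap of pyrrolidin-1-yl for 2-(piperidin-1-yl)ethyl gives the first comparison that differs in one place, and in this assay it produces a 330-fold lower number from compound 1 to compound 3 (2.52 log units; beyond the scatter) with the core of compound 1 unchanged. This shows that the amine chain alone can shift the binding number by a large margin, which the earlier pair, differing in more than one place, could not show. No supporting data bear on the reason for this step.

The change lengthens the chain and replaces the five-membered ring with a six-membered one, and the compounds shown do not separate these two differences. A 4-(pyrrolidin-1-yl)butyl chain or a 2-(piperidin-1-yl)ethyl chain ending instead in morpholine would be the next groups to compare at this position.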